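Capping the hydroxyl of compound 3 twice over

The source may hold more compounds than are shown below. What is called first, only, known or untested is meant among the compounds shown, and "the series" means these compounds.

Measured so far in an in vitro ADME assay on microsomes (Homo sapiens) for metabolic stability; a higher number here means that the compound lasts longer, a lower number that the compound disappears faster:
- compound 1 `CNC(=O)Nc1ccc(-c2nc(N3CC4CCC(C3)O4)c3cnn([C@H]4CC[C@@H](O)CC4)c3n2)cc1`: > 0.5 h (a limit)
- compound 2 `CNC(=O)Nc1ccc(-c2nc(N3CC4CCC(C3)O4)c3cnn([C@H]4CC[C@H](OC)CC4)c3n2)cc1`: 0.25 h
- compound 3 `CNC(=O)Nc1ccc(-c2nc(N3CC4CCC(C3)O4)c3cnn([C@H]4CC[C@H](O)CC4)c3n2)cc1`: > 0.5 h (a limit)

Compound 3 has no exact number, only the limit > 0.5 h. It stands at the limit of > 0.5 h in this assay, at which 2 of the 3 values shown sit. Compound 1 shares that limit, so a step that the two limits leave unreadable from compound 1 to compound 3 says nothing about the stereochemistry of the ring.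

Compound 4 `CNC(=O)Nc1ccc(-c2nc(N3CC4CCC(C3)O4)c3cnn(C4CCC(OC)(OC)CC4)c3n2)cc1` departs from compound 3 by a group of 10 heavy atoms (8 carbon, 2 oxygen; one six-membered non-aromatic ring of carbon only) in place of a group of 7 heavy atoms (6 carbon, 1 oxygen; one six-membered non-aromatic ring of carbon only), on an aromatic nitrogen. The 4-hydroxycyclohexyl leaves, and the group that enters has no common name.

The nearest evidence comes from compound 2, which has methyl on the oxygen where compound 3 has hydrogen. That step reads an at least 2.0-fold higher number from compound 2 to compound 3 (0.30 log units; that floor lies within the scatter), and the reverse change reads an at least 2.0-fold lower number from compound 1 to compound 2 (0.30 log units; that floor lies within the scatter). Within the data shown here, only floors can be read from these steps, but both point the same way: the compound with the capped oxygen, compound 2, holds the only exact number, 0.25 h.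

On that basis a lower number is expected in this assay, and the expected change is an at least 2.5-fold lower number from compound 3 to compound 4 (0.39 log units; beyond the scatter). Its size is only roughly known, as compound 3 has no exact number. For compound 4 the estimated half-life is 0.2 h, with an expected range of 0.09 h to 0.45 h.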

Compound 4, half-life: 0.5 h
Estimate against measurement, compound 4: 2.5-fold (0.40 log units) below; measured number above the stated range.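

In this assay compound 4 gives 0.5 h, so a second capped group on the aromatic nitrogen now has an exact number, and the comparison of the two capped compounds reads a 2.0-fold higher number from compound 2 to compound 4 (0.30 log units; within the scatter), so at this position the group with no common name cannot be told apart from the 4-methoxycyclohexyl of compound 2, and the added oxygen on the ring leaves no readable mark. The other two steps read a number no higher from compound 3 to compound 4 (the limit leaves the size open) and a number no higher from compound 1 to compound 4 (the limit leaves the size open), and neither can be read in size, because the values of both those starting compounds are limits and not numbers: the limit of > 0.5 h in this assay, at which 2 of the 4 values shown sit.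

As far as these compounds go, how far the two hydroxyl compounds, compound 1 and compound 3, lie from the capped ones therefore stays open, since neither has an exact number in this assay. The compounds shown also do not tell how an amine or a pair of fluorine atoms in place of the oxygens on the cyclohexyl ring would fare at this position.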